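This account rests on a few compounds, and the source may have more. Where it says the series, first, only, none or still open, it means among the compounds named here.

Among the measured compounds shown here, compound 2 `CC(=O)Oc1ccc2c(c1)C(n1ccccc1=O)=CC(C)(C)O2` gives 5.6 in a functional assay (aorta) with Rattus norvegicus as the target (a lower number here means a less potent compound, a higher number a more potent compound, by a factor of ten per unit of this negative logarithm), the lowest of the two numbers measured so far. Its nearest neighbour is compound 1 `CC1(C)C=C(n2ccccc2=O)c2cc(C(=O)c3ccco3)ccc2O1` at 6.49; the step of a number 0.89 log units lower from compound 1 to compound 2 (beyond the scatter) is a modest loss, going with acetoxy in place of (furan-2-yl)carbonyl on an aromatic carbon.

Compound 3 `CC1(C)C=C(n2ccccc2=O)c2cc(OC(=O)Nc3ccccc3C(F)(F)F)ccc2O1` is still to be measured. It differs from compound 2 by (2-(trifluoromethyl)phenyl)amino in place of methyl on a carbonyl carbon. For the measured compounds named here, no measured step matches this change; the single step known, a number 0.89 log units lower from compound 1 to compound 2 (beyond the scatter), shows only that exchanging the group on that aromatic carbon moves this assay by a modest amount, and that the larger ring-bearing group of compound 1 gave the higher number. On that slim basis a modest gain is expected from compound 2 to compound 3, a number 0.50 log units higher from compound 2 to compound 3 (beyond the scatter), with wide uncertainty. The estimate for compound 3 is 6.1, expected to fall between 5.3 and 6.9.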

Compound 3, logarithm of the reciprocal of the active concentration, log(1/C): 5.58
Beside the measured number, compound 3's estimate is 0.52 log units above it; measured number inside the range.
By their numbers in this assay, from the lowest: compounds 3 and 2 (each within the scatter of the next); then compound 1.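

In this assay, the exchange on the carbonyl carbon gives a number 0.02 log units lower from compound 2 to compound 3 (within the scatter), so adding the (2-(trifluoromethyl)phenyl)amino group, with its six-membered aromatic ring and hydrogen-bond donor, leaves the read-out within the scatter of the methyl compound. A ring in the group carried on that aromatic carbon is therefore not enough on its own to reach the number of compound 1 at 6.49, and the link between larger ring-bearing groups and higher numbers suggested by the first step does not hold for compound 3. No measurement at hand bears on why this step is so small.

The compounds shown leave open whether the number of compound 1 depends on the furan ring or on the carbonyl joined directly to the aromatic carbon. A benzoyl group or a simple amine at that position would help to separate these two readings.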